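Hexyl in Place of Phenyl: an Estimate Before Measurement

The source may hold more compounds than are shown below. What is called first, only, known or untested is meant among the compounds shown, and "the series" means these compounds.

Compound 1 `c1ccc(CCc2cccc(N3CCNCC3)n2)cc1` — > 300 mg/kg
Compound 2 `CC(C)(C)c1cccc(N2CCNCC2)n1` — > 300 mg/kg
Compound 3 `CCCCSc1cccc(N2CCNCC2)n1` — 100 mg/kg

All three compounds were tested in a functional assay on the whole organism with Mus musculus as the target, in the maximal electroshock model, with a stated time of 120 min; on this read-out higher numbers stand for an effect only at larger amounts of compound and lower numbers for an effect already at smaller amounts. For compound 1 the value > 300 mg/kg is a limit of the assay, not a number. Compound 2 likewise gives only the limit > 300 mg/kg. Compound 3 gives 100 mg/kg. Compound 1 therefore stands at the limit (the limit of > 300 mg/kg in this assay, at which 2 of the 3 values shown sit), alongside compound 2, while compound 3 alone gives a number. Among the measured compounds shown here, the single measured step, an at least 3.0-fold lower number from compound 2 to compound 3 (0.47 log units; beyond the scatter), exchanges one group for another on an aromatic carbon and does not touch the chain.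

Compound 4 `CCCCCCCCc1cccc(N2CCNCC2)n1` differs from compound 1 by hexyl in place of phenyl on a saturated chain carbon, two bonds along the chain from an aromatic carbon. For the measured compounds named here, no measured step bears on this change, so the data give no direction for it, and compound 1 itself offers only a limit as a starting point. The estimate for compound 4 is 200 mg/kg, with a range from 80 mg/kg to 500 mg/kg. This estimate corresponds to an expected step of an at least 1.5-fold lower number from compound 1 to compound 4 (0.17 log units; that floor lies within the scatter). A further limit rather than a number is also considered likely for compound 4.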

Compound 4, minimum effective dose: 10 mg/kg
Compound 4: middle estimate off by 20-fold (1.30 log units), on the high side; the whole stated range lies above it.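

Among the compounds shown here, at this place, on a saturated chain carbon, two bonds along the chain from an aromatic carbon, the earlier compounds offered no measured change; in this assay, hexyl in place of phenyl now gives an at least 30-fold lower number from compound 1 to compound 4 (1.47 log units; beyond the scatter). The two groups match in their counts of heavy atoms, hydrogen-bond donors and hydrogen-bond acceptors, so the step goes with the loss of the aromatic ring and not with a change in those counts. The step is only a floor, for compound 1 rests on a limit of the assay and not on a number: the limit of > 300 mg/kg in this assay, at which 2 of the 4 values shown sit.

The compounds shown leave open whether cyclohexyl in place of phenyl would behave like hexyl, which would separate the loss of the ring from the loss of its aromatic character. They also leave open how a longer chain in place of hexyl would read out.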